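Trading a ring for an open chain

The source may report more compounds than this note shows. Statements on the series, on what has been measured and on what is new or still open speak of the compounds shown alone.

- compound 1 (`O=C(/C=C/c1ccc(NC(=O)Nc2ccc(Cl)c(C(F)(F)F)c2)cc1)NC1CCC1`): 17300 nM
- compound 2 (`CNC(=O)c1cccc(-c2ccc(NC(=O)Nc3ccc(Cl)c(C(F)(F)F)c3)cc2)c1`): 39300 nM

In a functional assay on KETR3 cells (Homo sapiens) for inhibition, read by MTT assay, with a stated time of 120 h (on this read-out lower numbers stand for stronger inhibition and higher numbers for weaker inhibition), compound 2 has the higher of the two numbers, so it is the weaker inhibitor of this pair. Compound 3 (`CNC(=O)CCc1ccc(NC(=O)Nc2ccc(Cl)c(C(F)(F)F)c2)cc1`) changes one group on the shared core: 2-(methylcarbamoyl)ethyl in place of 3-(methylcarbamoyl)phenyl on an aromatic carbon. For the measured compounds named here, only one measured step bears on this change, a 2.3-fold higher number from compound 1 to compound 2 (0.36 log units; beyond the scatter), where 3-(methylcarbamoyl)phenyl replaced the open chain 2-(cyclobutylcarbamoyl)ethenyl. Compound 3 goes the opposite way, from that ring back to an open chain, though not the same chain. A step of similar modest size toward lower numbers is therefore expected, with wide uncertainty, as it rests on a single comparison. The expected step is a 2.2-fold lower number from compound 2 to compound 3 (0.34 log units; beyond the scatter) (an estimate, not a measurement). The estimate for compound 3 is 18000 nM (range 7000 nM to 45000 nM).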

Compound 3, half-maximal inhibitory concentration: 24000 nM
Beside the measured number, compound 3's estimate is 1.3-fold (0.12 log units) below it; the measured number falls inside the stated range.
By their numbers in this assay, from the lowest: compounds 1, 3 and 2 (each within the scatter of the next, the first and the last beyond it).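

In this assay the 2-(methylcarbamoyl)ethyl group keeps the methylcarbamoyl end of the 3-(methylcarbamoyl)phenyl group but has no ring, and the result is a 1.6-fold lower number from compound 2 to compound 3 (0.21 log units; within the scatter). On this evidence, the ring is not needed at this position to reach this level of inhibition. The comparison with the unsaturated chain carrying a cyclobutyl amide gives a 1.4-fold higher number from compound 1 to compound 3 (0.14 log units; within the scatter), so compound 3 cannot be told apart from either compound 1 or compound 2, and no data shown here give a reason for this.

Still open, as far as these compounds go, is whether a longer chain ending in the same methylcarbamoyl group would separate clearly from these three. It is equally unknown how a carboxylic acid or an amine at the end of the chain would behave in this position.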